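From ethoxy to isopropoxy on a shared core

This account rests on a few compounds, and the source may have more. Where it says the series, first, only, none or still open, it means among the compounds named here.

Compound 1 `COc1cc(-n2ncnc2-c2ccc(Cl)cc2)cc(OC)c1OC`: > 10000 nM (a limit of the assay)
Compound 2 `CCOc1ccc(-c2ncnn2-c2cc(OC)c(OC)c(OC)c2)cc1`: 20 nM
Compound 3 `COc1cc(-n2ncnc2-c2ccc(OC(C)C)cc2)cc(OC)c1OC`: not yet measured

Among the measured compounds shown here, in a functional assay on K562 cells (Homo sapiens) for antiproliferative activity, read by MTT assay, with a stated time of 72 h (a higher number here means a weaker inhibitor, a lower number a stronger inhibitor), compound 2 gives 20 nM, the only actual number so far. Compound 1 reads > 10000 nM, which is a limit and not a number. For the measured compounds named here, the single measured step, with ethoxy in place of chloro on an aromatic carbon, is an at least 500-fold lower number from compound 1 to compound 2 (2.69 log units; beyond the scatter). It is large, and it shows that this substituent can move the read-out strongly, though it starts from the limit of > 10000 nM in this assay, at which 1 of the 2 values shown sits.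

Compound 3 changes the same group: methyl in place of hydrogen on a saturated chain carbon bound to an oxygen on an aromatic ring and a saturated chain carbon, so ethoxy becomes isopropoxy. This is a much smaller edit than the measured one, and compound 2 already sits low at 20 nM. A moderate move towards weaker inhibition is therefore expected, and the estimated step is a 6.0-fold higher number from compound 2 to compound 3 (0.78 log units; beyond the scatter). Compound 3 is expected at 120 nM, with an estimated range from 25 nM to 1000 nM.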

Compound 3, half-maximal inhibitory concentration: 800 nM
Beside the measured number, compound 3's estimate is 6.7-fold (0.82 log units) below it; the range from low to high includes it.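

The result shows that this position responds not only to replacing chloro with an alkoxy group, but also to a single methyl in place of hydrogen on the saturated chain carbon bound to the oxygen: in this assay, ethoxy to isopropoxy gives a 40-fold higher number from compound 2 to compound 3 (1.60 log units; beyond the scatter). Isopropoxy still reads well clear of chloro, with an at least 12-fold lower number from compound 1 to compound 3 (1.09 log units; beyond the scatter), so the two alkoxy groups both improve on chloro yet are far from equivalent. The value of compound 1 is a limit, so this last step is a bound only: the limit of > 10000 nM in this assay, at which 1 of the 3 values shown sits.

The compounds shown leave open how methoxy or a longer chain such as n-propoxy would read here, and so whether ethoxy marks a best point in the series. They also leave open whether a hydroxyl or an amine could take the place of these groups.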